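Shifting a Hydroxyl Group: From Compound 2 to Compound 4

A few compounds are considered here, and "the series" means these few. Any claim that something is new, unique, unknown or untested is made for them only; others in the source may bear on it.

Three compounds have been measured in an ADME assay on L929 cells (Mus musculus) for cytotoxicity, read by resazurin assay, with a stated time of 72 h; on this read-out higher numbers stand for weaker inhibition and lower numbers for stronger inhibition:
Compound 1 `CCc1ccc(C(=O)/C=C/c2ccc3c(c2)B(O)OC3)cc1`: > 10 ug/mL
Compound 2 `O=C(/C=C/c1ccc2c(c1)B(O)OC2)c1ccccc1O`: > 10 ug/mL
Compound 3 `COc1cccc(C(=O)/C=C/c2ccccc2)c1`: 5.7 ug/mL

Compound 2 gives only a limit in this assay, > 10 ug/mL, and not a number. Compound 1 likewise returns only a limit, > 10 ug/mL. Among the measured compounds shown here, compound 3 is the one compound with a number, 5.7 ug/mL. Two of the three values thus sit at the limit of > 10 ug/mL in this assay, at which 2 of the 3 values shown sit.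

Compound 4 `O=C(/C=C/c1ccc2c(c1)B(O)OC2)c1cccc(O)c1` is not yet measured. It differs from compound 2 by 3-hydroxyphenyl in place of 2-hydroxyphenyl on a carbonyl carbon. For the measured compounds named here, no measured pair shows what this change does in this assay, so the expected step from compound 2 to compound 4 is taken as none beyond the scatter, a step that the limit leaves unreadable from compound 2 to compound 4. Compound 4 is therefore estimated at 12 ug/mL, between 5 ug/mL and 30 ug/mL, most likely again reported as a limit.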

Compound 4, half-maximal inhibitory concentration: 7.56 ug/mL
Beside the measured number, compound 4's estimate is 1.6-fold (0.20 log units) above it, within the range that was stated.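

Among the compounds shown here, with 3-hydroxyphenyl in place of 2-hydroxyphenyl on the carbonyl carbon, compound 4 is the one compound with this core that gives a number rather than a limit in this assay. The change amounts to an at least 1.3-fold lower number from compound 2 to compound 4 (0.12 log units; that floor lies within the scatter), so even this floor does not separate the two compounds. The true size of the step stays unread because compound 2 gives only a limit: the limit of > 10 ug/mL in this assay, at which 2 of the 4 values shown sit.

Going by these compounds, what 4-hydroxyphenyl, or an amine or a carboxylic acid in place of the hydroxyl, would do on this carbonyl carbon remains open.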